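Amide in place of amine on the side chain of compound 2

The source may hold more compounds than are shown below. What is called first, only, known or untested is meant among the compounds shown, and "the series" means these compounds.

Compound 1 `CNCc1ccc2ccc(Cl)c(C3=C(c4cn(C)c5ccccc45)C(=O)NC3=O)c2c1` and compound 2 `COCCNCc1ccc2ccc(Cl)c(C3=C(c4cn(C)c5ccccc45)C(=O)NC3=O)c2c1` share one core and differ only in the chain on the saturated chain carbon bound to the amine nitrogen. In an assay on isolated protein for inhibition of protein kinase C epsilon type (Homo sapiens), read by scintillation proximity assay and 33P incorporation, with a stated time of 60 min, in the presence of a further agent that is not named here (on this read-out higher numbers stand for weaker inhibition and lower numbers for stronger inhibition), compound 1 gives 30 nM, while compound 2 gives 110 nM, the higher of the two numbers; the step of a 3.7-fold higher number from compound 1 to compound 2 (0.56 log units; beyond the scatter) lies beyond the scatter. Compound 3 `CC(=O)N(C)Cc1ccc2ccc(Cl)c(C3=C(c4cn(C)c5ccccc45)C(=O)NC3=O)c2c1` has not yet been measured. It differs from compound 2 by acetyl(methyl)amino in place of (2-methoxyethyl)amino on a saturated chain carbon bound to an aromatic carbon, so the nitrogen that carried the methoxyethyl chain in compound 2 now carries an acetyl and a methyl group. Going by the values given here, only the step from compound 1 to compound 2 bears on this change, and it concerns the same place but a different kind of exchange, so no measured step matches it directly. Because the step of a 3.7-fold higher number from compound 1 to compound 2 (0.56 log units; beyond the scatter) already weakened inhibition when the chain grew, compound 3 is expected to show a 1.8-fold higher number from compound 2 to compound 3 (0.26 log units; within the scatter). Compound 3 in this assay is estimated at 200 nM, with a range from 50 nM to 800 nM.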

Compound 3, half-maximal inhibitory concentration: > 316 nM
Compound 3 was reported as a limit; the forecaster's own chance of this, stated with the estimate: 5%; at least 1.5-fold (0.19 log units) between middle value and limit.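

In this assay compound 3 is reported only as a limit, not as a number: the limit of > 316 nM in this assay, at which 1 of the 3 values shown sits. Exchanging (2-methoxyethyl)amino for acetyl(methyl)amino gives an at least 2.8-fold higher number from compound 2 to compound 3 (0.45 log units; beyond the scatter), and acetyl in place of hydrogen on the amine nitrogen gives an at least 10-fold higher number from compound 1 to compound 3 (1.02 log units; beyond the scatter). The earlier pair showed a weakening only while the nitrogen stayed an amine; here the nitrogen becomes an amide, and inhibition weakens further although the leaving and entering groups both count 5 heavy atoms, so that count does not set the number at this position.

From the compounds shown here alone, how far the weakening extends past the limit stays open. Going by these compounds, it also stays open whether the acetyl group or the loss of the amine hydrogen carries the change, which a dimethylamine or an amide without the methyl on its nitrogen would separate.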